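Nitro for trichloromethyl on the aryl ether tail

A few compounds are considered here, and "the series" means these few. Any claim that something is new, unique, unknown or untested is made for them only; others in the source may bear on it.

Two compounds of the series carry numbers in a physicochemical assay for lipophilicity; on this read-out higher numbers stand for higher lipophilicity and lower numbers for lower lipophilicity. Compound 1 `CC(=O)Nc1ccc(OC(=S)Nc2ccc(Nc3ccc(C(F)(F)F)cc3)cc2)cc1` gives 5.32 in this assay. Compound 2 `CC(=O)Nc1ccc(OC(=S)Nc2ccc(Oc3ccc(C(Cl)(Cl)Cl)cc3)cc2)cc1` gives 6.16 in this assay, the higher of the two values, with the gap to compound 1 beyond the scatter; the two compounds differ in more than one place, so nothing more is read from the pair. Compound 3 `CC(=O)Nc1ccc(OC(=S)Nc2ccc(Oc3ccc([N+](=O)[O-])cc3)cc2)cc1` has not yet been measured in this assay. Against compound 2 it differs by nitro in place of trichloromethyl on an aromatic carbon. Going by the values given here, no measured pair isolates this change, so the expected size rests on the change alone. A clear fall in this assay is expected, well beyond the scatter, and the step from compound 2 to compound 3 that the estimate means is a number 1.96 log units lower from compound 2 to compound 3 (beyond the scatter). For compound 3 the expected value in this assay is 4.2, with a range from 3.6 to 4.8. Once the number is in hand, the step can be set against the other two values.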

Compound 3, partition coefficient: 4.81
For compound 3 the middle estimate is 0.61 log units below the measured one, and the stated range ends below it.
By their numbers in this assay, from the lowest: compound 3; then compound 1; then compound 2.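

In this assay, replacing trichloromethyl with nitro on the aromatic carbon para to a large group gives a number 1.35 log units lower from compound 2 to compound 3 (beyond the scatter). Going by these compounds alone, this is the first step that changes one place only, so it shows that the read-out responds strongly to this position while the rest of the structure stays fixed. The entering nitro also brings hydrogen-bond acceptors where the leaving trichloromethyl has none, but nothing available accounts for the size of the step.

Compound 1 differs from compound 3 in more than one place, so no step can be read between them, and the series does not show whether the same change gives a similar step when the aryl ether oxygen is replaced by the amine linkage of compound 1. A carboxylic acid, an amine or a nitrile on the same aromatic carbon would show how far the read-out moves with other replacements of trichloromethyl, since a single step cannot define a trend at this position.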